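The compounds below may be only part of what the source reports. "The series", "measured", "known", "first", "only" and "open" are said of these compounds alone.

Going by the values given here, compound 1 `CCCCCCCCCCCCCCCCOP(=O)(O)OCCSC(=S)N1CCCCC1` is the only member of this small set with a numerical result: in a functional assay on MDA-MB-231 cells (Homo sapiens) for inhibition, read by MTT assay, with stated times of 18 h and 4 h (on this read-out lower numbers stand for stronger inhibition and higher numbers for weaker inhibition), compound 1 gives 100000 nM. Compound 2 `CCCCCCCCCCCCCCCCOP(=O)(O)OCCSC(=S)N1CCN(C)CC1` reaches only a limit of the assay, > 100000 nM. Compound 3 `CCCCCCCCCCCCCCCCOP(=O)(O)OCCSC(=S)N1CCCCCC1` likewise sits at a limit, > 100000 nM. The step of a number no lower from compound 1 to compound 2 (the limit leaves the size open) and the step of a number no lower from compound 1 to compound 3 (the limit leaves the size open) are therefore left open in size, and the two limits sit at the limit of > 100000 nM in this assay, at which 2 of the 3 values shown sit.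

Compound 4 `CCCCCCCCCCOP(=O)(O)OCCSC(=S)N1CCCCC1` differs from compound 1 in one place, (hydrogen in place of hexyl on a saturated chain carbon, ten or more bonds along the chain from an oxygen on an unsaturated carbon). Among the compounds with values here, the three measured compounds change only the ring on the thiocarbonyl carbon; none of them alters the long chain, so no measured step bears directly on this change. The expectation for compound 4 rests on compound 1 alone, whose value already stands at the top of the range that was resolved. With nothing pointing either way, the step of no change at the digits printed from compound 1 to compound 4 (within the scatter) is expected to stay within the scatter, and compound 4 is estimated at 100000 nM in this assay, between 30000 nM and 300000 nM, with a real chance that only a limit is reported.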

Compound 4, half-maximal inhibitory concentration: 24600 nM
Estimate against measurement, compound 4: 4.1-fold (0.61 log units) above, and the stated range ends above it.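

The long chain turns out to matter in this assay: hydrogen in place of hexyl on a saturated chain carbon gives a 4.1-fold lower number from compound 1 to compound 4 (0.61 log units; beyond the scatter). Going by these compounds alone, on this read-out a lower number stands for stronger inhibition, so the shorter chain of compound 4 gives a modest gain, and this is the first change in the set whose size can be read. The ring changes on the thiocarbonyl carbon still cannot be read, because their steps end at a limit of the assay: the limit of > 100000 nM in this assay, at which 2 of the 4 values shown sit.

Going by these compounds, one step does not make a trend, so it remains open how an octyl or a dodecyl chain would compare with the chain of compound 4. Also open, on these data alone, is whether azepan-1-yl or 4-methylpiperazin-1-yl, paired with that shorter chain, would give a readable number.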